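A few compounds are considered here, and "the series" means these few. Any claim that something is new, unique, unknown or untested is made for them only; others in the source may bear on it.

Compound 1 `O=C1NCc2c1c1c(c3c2c2ccccc2n3CCO)CCc2cc(OCc3ccccn3)ccc2-1`: 36%
Compound 2 `O=C1NCc2c1c1c(c3c2c2ccccc2n3CCO)CCc2cc(OCCOCc3ccccc3)ccc2-1`: 9%

In an assay on isolated protein for inhibition of mitogen-activated protein kinase kinase kinase 9 (Homo sapiens), tested at 1 uM (on this read-out lower numbers stand for less inhibition and higher numbers for more inhibition at the one concentration tested (going by the name of the read-out)), compound 1 gives 36% and stands highest of the two numbers; compound 2 gives 9%. Among the compounds with values here, the one measured step, a number 27 percentage points lower from compound 1 to compound 2 (beyond the scatter), goes downward beyond the scatter. Compound 3 `N#CCCCOc1ccc2c(c1)CCc1c-2c2c(c3c4ccccc4n(CCO)c13)CNC2=O` differs from compound 1 by 2-cyanoethyl in place of pyridin-2-yl on a saturated chain carbon bound to an oxygen on an aromatic ring. Within the data shown here, this is the same place as the step to compound 2, so a drop is expected rather than a gain; with only one step to lean on, the size is uncertain. For compound 3 the expected step is a number 18 percentage points lower from compound 1 to compound 3 (beyond the scatter), giving an estimate of 18% with a range from 2% to 36%.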

Compound 3, a percentage reported as inhibition, at one concentration (the size of the read-out at that concentration, not a potency): 58%
Estimate against measurement, compound 3: 40 percentage points below, and the stated range ends below it.
By their numbers in this assay, from the lowest: compound 2; then compound 1; then compound 3.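

This position is not one where every departure from pyridin-2-yl loses: a number 22 percentage points higher from compound 1 to compound 3 (beyond the scatter) in this assay with 2-cyanoethyl in its place, so a ring on this chain is not required for the higher number. Among the two open-chain ethers the end group matters strongly, with a number 49 percentage points higher from compound 2 to compound 3 (beyond the scatter) for cyanomethyl in place of benzyloxy. Nothing available explains these differences.

Open, on these data alone, is whether the gain follows the nitrile or the chain length. An amine or a carboxylic acid at the end of the same chain, or a longer chain ending in nitrile, would separate the two.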